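The source may report more compounds than this note shows. Statements on the series, on what has been measured and on what is new or still open speak of the compounds shown alone.

Compound 3, whose structure is `COc1ccc(C2CC(c3cc(OC)c(OC)c(OC)c3)=NN2C(C)=O)cc1O`, gives in a functional assay on B16 cells (Mus musculus) for cytotoxicity, read by MTT assay, with a stated time of 72 h (on this read-out lower numbers stand for stronger inhibition and higher numbers for weaker inhibition), only the limit > 100000 nM, not a number. Compound 2, with the structure `COc1ccc(OC)c(C2CC(c3cc(OC)c(OC)c(OC)c3)=NN2C(C)=O)c1`, likewise reaches only the limit > 100000 nM in this assay. Going by the values given here, the one measured number belongs to compound 1, built as `COc1cc(C2=NN(C(C)=O)C(c3ccc(Cl)cc3)C2)cc(OC)c1OC`, which gives 35000 nM in this assay. From compound 1 the steps were an at least 2.8-fold higher number from compound 1 to compound 2 (0.45 log units; beyond the scatter) and an at least 2.8-fold higher number from compound 1 to compound 3 (0.45 log units; beyond the scatter), both pointing toward weaker inhibition. The step that the two limits leave unreadable from compound 2 to compound 3 stays unreadable because of the limit of > 100000 nM in this assay, at which 2 of the 3 values shown sit.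

Compound 4, drawn as `COc1cccc(C2CC(c3cc(OC)c(OC)c(OC)c3)=NN2C(C)=O)c1`, differs from compound 3 by one change: 3-methoxyphenyl in place of 3-hydroxy-4-methoxyphenyl on a saturated ring carbon. Two changes of the aryl group on that same saturated ring carbon each pushed the number up to the limit, and none of them offers a read on the hydroxyl alone, so the expectation for compound 4 rests on weak inhibition overall. The expected step is an at least 1.1-fold lower number from compound 3 to compound 4 (0.04 log units; that floor lies within the scatter), within the scatter. The estimate for compound 4 in this assay is therefore 90000 nM, with a range from 30000 nM to 200000 nM, and a real chance that only the limit is reported again.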

Compound 4, half-maximal inhibitory concentration: > 100000 nM
Compound 4 ended at the assay's limit (the forecaster's own chance of this, stated with the estimate: 55%); middle value at least 1.1-fold (0.04 log units) from the limit.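

The 3-methoxyphenyl group is the third oxygen-bearing aryl group on this saturated ring carbon to give no number, and with 0 hydrogen-bond donors it shows that the hydroxyl of compound 3 is not needed for that outcome. Set against the 4-chlorophenyl group, this change gives an at least 2.8-fold higher number from compound 1 to compound 4 (0.45 log units; beyond the scatter), so among the four compounds only the chlorinated compound 1 has a measured number in this assay. The steps among compounds 2, 3 and 4 cannot be read, and any difference between these three aryl groups stays hidden: the limit of > 100000 nM in this assay, at which 3 of the 4 values shown sit.

Open, on these data alone, is whether the chlorine itself matters, or whether a plain phenyl ring or a bromophenyl group on the same carbon would also give a number. An aminophenyl group there could show whether a different kind of substituent gives a stronger result.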